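This account rests on a few compounds, and the source may have more. Where it says the series, first, only, none or still open, it means among the compounds named here.

Compound 1 (`Nc1cn(COC(CO)CO)c(=O)[nH]c1=O`) is the reference point in a functional assay on Vero cells (Chlorocebus sabaeus) for cytotoxicity; on this read-out higher numbers stand for lower toxicity in this test and lower numbers for higher toxicity in this test. Compound 1 gives > 432000 nM, which is a limit and not a number. Compound 2 (`CCc1cn(COC(CO)CO)c(=O)[nH]c1=O`) gives > 410000 nM, also a limit. Compound 3 (`O=c1[nH]c(=O)n(COC(CO)CO)cc1CO`) gives > 406000 nM, again a limit. Compound 1 therefore has no exact value, and neither do its two neighbours. Compound 4 (`O=c1[nH]c(=O)n(COC(CO)CO)cc1CCO`) carries 2-hydroxyethyl in place of amino on an aromatic carbon. The closest measured changes are a step that the two limits leave unreadable from compound 1 to compound 2 and a step that the two limits leave unreadable from compound 1 to compound 3, and neither has a readable size. Neither replacement brought a numerical reading in this assay, so no real shift is expected. The expected change is an at least 1.0-fold lower number from compound 1 to compound 4 (0.03 log units; that floor lies within the scatter), within the scatter. For compound 4 the estimated value is 400000 nM, ranging from 250000 nM to 650000 nM, and it will probably be reported as a limit.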

Compound 4, half-maximal cytotoxic concentration: > 384000 nM
Compound 4: only a limit was reported (the forecaster's own chance of this, stated with the estimate: 90%); the middle value lies beyond the limit too.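

In this assay, compound 4, like compound 1, compound 2 and compound 3, is reported only as a limit, so no step among these four can be read. The compounds shown leave open at what concentration any of them becomes toxic, and whether swapping these groups changes that concentration.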